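The source may report more compounds than this note shows. Statements on the series, on what has been measured and on what is new or still open speak of the compounds shown alone.

Three compounds share one core. Compound 1, `CSCC[C@H](NC(=O)CN(c1nc(Cl)nc2[nH]cnc12)C1CC1)C(=O)OCc1ccccc1`, carries a 2-(methylsulfanyl)ethyl group on the saturated chain carbon bound to an amide-type nitrogen and a carbonyl carbon, and in a functional assay on the whole organism (Tail, strain ICR) with Mus musculus as the target, in the tail flick test, with a stated time of 30 min, at a dose of 25 umol/kg by the oral route (on this read-out lower numbers stand for a weaker effect and higher numbers for a stronger effect at the one dose given), compound 1 gives 22.2%. Compound 2, `NCCCC[C@H](NC(=O)CN(c1nc(Cl)nc2[nH]cnc12)C1CC1)C(=O)OCc1ccccc1`, gives 26.1% in this assay, while compound 3, `O=C(CN(c1nc(Cl)nc2[nH]cnc12)C1CC1)NCC(=O)OCc1ccccc1`, which bears hydrogen at that carbon, gives 18.7%. Compound 3 thus holds the lowest of the three numbers, yet its gap to compound 1 and its gap to compound 2 both fall within the scatter, so no order among them can be read.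

Compound 4, `O=C(CN(c1nc(Cl)nc2[nH]cnc12)C1CC1)N[C@@H](CCC(=O)OCc1ccccc1)C(=O)OCc1ccccc1`, differs from compound 3 in one place: 2-(benzyloxycarbonyl)ethyl in place of hydrogen on a saturated chain carbon bound to an amide-type nitrogen and a carbonyl carbon. Among the measured compounds shown here, two measured steps touch the same carbon. The step of a number 3.5 percentage points lower from compound 1 to compound 3 (within the scatter) and the step of a number 7.4 percentage points lower from compound 2 to compound 3 (within the scatter) both strip a side chain down to hydrogen, and neither moves beyond the scatter; the step of a number 3.9 percentage points higher from compound 1 to compound 2 (within the scatter) swaps one side chain for another, again within the scatter. Nothing measured here shows a side chain at this carbon mattering, so for compound 4 the expected step is a number 3.3 percentage points higher from compound 3 to compound 4 (within the scatter), none beyond the scatter. Compound 4 is therefore estimated at 22%, within 10% to 35%.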

Compound 4, a percentage reported as activity, at one dose (the size of the read-out at that dose, not a potency): 52.8%
Beside the measured number, compound 4's estimate is 30.8 percentage points below it, and the stated range ends below it.
By their numbers in this assay, from the lowest: compounds 3, 1 and 2 (each within the scatter of the next); then compound 4.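

The carbon bound to an amide-type nitrogen and a carbonyl carbon proves sensitive to its side chain in this assay after all: 2-(benzyloxycarbonyl)ethyl in place of hydrogen gives a number 34.1 percentage points higher from compound 3 to compound 4 (beyond the scatter), the only step from hydrogen at this carbon shown beyond the scatter. The side chains of compound 1 and compound 2 stay within the scatter of hydrogen, and the new side chain stands clear of both, with a number 26.7 percentage points higher from compound 2 to compound 4 (beyond the scatter) and a number 30.6 percentage points higher from compound 1 to compound 4 (beyond the scatter), so carrying just any chain at this carbon does not give the gain. Nothing at hand explains the gain.

The compounds shown leave open whether the benzyl ester of the side chain is needed, or whether a free carboxylic acid or a methyl ester there would hold the gain. They also leave open how a shorter or longer chain carrying the benzyloxycarbonyl group would read.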